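This account rests on a few compounds, and the source may have more. Where it says the series, first, only, none or still open, it means among the compounds named here.

Among the measured compounds shown here, in an ADME assay on J774 cells (Mus musculus) for cytotoxicity, with a stated time of 72 h (a higher number here means that more compound is needed for the effect, a lower number that less compound is needed), the compounds measured so far all share one core and all end at limits. Compound 1 (`COc1cc2[nH]c(C)c(-c3cccnc3)c(=O)c2cc1Cl`) gives > 33300 nM as a limit of the assay. Compound 2 (`COc1cc2[nH]c(C)c(-c3cncnc3)c(=O)c2cc1Cl`) gives > 33100 nM and this too is a limit. Compound 3 (`COc1cc2[nH]c(C)c(-c3ccc(N(C)C)nc3)c(=O)c2cc1Cl`) gives > 29100 nM as a limit, so it has no number of its own and stands with the other two at a limit. Compound 4 (`COc1cc2[nH]c(C)c(-c3ccc(N4CCN(C)CC4)nc3)c(=O)c2cc1Cl`) carries 4-methylpiperazin-1-yl in place of dimethylamino on an aromatic carbon next to the ring nitrogen, a change counted as 4-methylpiperazin-1-yl in place of dimethylamino on an aromatic carbon and not yet measured. For the measured compounds named here, two measured steps bear on it, a step that the two limits leave unreadable from compound 1 to compound 2 and a step that the two limits leave unreadable from compound 1 to compound 3 and neither has a readable size. They give no size to carry over, so no step beyond the scatter is expected in this assay and a further limit is likely. The expected step is an at least 1.1-fold lower number from compound 3 to compound 4 (0.06 log units; that floor lies within the scatter) and it remains an estimate. For compound 4 the estimated value is 25000 nM with an expected range from 10000 nM to 38000 nM around it.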

Compound 4, half-maximal effective concentration: > 25100 nM
Compound 4: no number, only a limit; the forecaster's own chance of this, stated with the estimate: 70%; middle value at least 1.0-fold (0.00 log units) from the limit.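

Compound 4 also ends at a limit in this assay, so the steps to it from compound 3 and from compound 1 cannot be read. The compounds shown leave open what concentration gives the half-maximal effect for any of them, and whether 4-methylpiperazin-1-yl in place of dimethylamino shifts it.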